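The source may hold more compounds than are shown below. What is called first, only, known or untested is meant among the compounds shown, and "the series" means these compounds.

Measured compounds:
compound 1, `Cc1nc2cc(NC(=O)N3CCN(Cc4cccc(Oc5ccc(Cl)cc5)c4)CC3)ccc2o1`, 7.7 nM in an assay on isolated protein for inhibition of Fatty-acid amide hydrolase 1 (Homo sapiens), with a stated time of 60 min; on this read-out lower numbers stand for stronger inhibition and higher numbers for weaker inhibition
compound 2, `O=C(Nc1cncc2ccccc12)N1CCN(Cc2cccc(Oc3ccc(Cl)cc3)c2)CC1`, 6.7 nM in this assay
compound 3, `O=C(Nc1cn2ccccc2n1)N1CCN(Cc2cccc(Oc3ccc(Cl)cc3)c2)CC1`, > 10000 nM in this assay

Compound 3 stands apart from the other two: its value in this assay is a limit of the assay and not a number, so only a lower bound is known. The two measured steps that reach it are both large and in the same direction, an at least 1200-fold higher number from compound 1 to compound 3 (3.11 log units; beyond the scatter) and an at least 1400-fold higher number from compound 2 to compound 3 (3.17 log units; beyond the scatter); the step of a 1.1-fold lower number from compound 1 to compound 2 (0.06 log units; within the scatter) is within the scatter, so the two compounds sharing the shorter group on the amide-type nitrogen sit together, as the limit of > 10000 nM in this assay, at which 1 of the 3 values shown sits, marks where compound 3 sits.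

Compound 4, `O=C(Nc1cccn2ccnc12)N1CCN(Cc2cccc(Oc3ccc(Cl)cc3)c2)CC1`, has not been measured. It differs from compound 3 in that (a group of 9 heavy atoms (7 carbon, 2 nitrogen; one five-membered aromatic ring with 2 hetero atoms, one six-membered aromatic ring with 1 hetero atom) in place of a group of 9 heavy atoms (7 carbon, 2 nitrogen; one five-membered aromatic ring with 2 hetero atoms, one six-membered aromatic ring with 1 hetero atom), on an amide-type nitrogen); the two have the same atoms, joined differently. Going by the values given here, no measured step concerns this rearrangement, so the two large steps into compound 3 give only the spread of numbers seen across the set. Compound 4 is therefore expected to move by an at least 66-fold lower number from compound 3 to compound 4 (1.82 log units; beyond the scatter), and its estimated value in this assay is 150 nM, between 10 nM and 5000 nM.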

Compound 4, half-maximal inhibitory concentration: 310 nM
The estimate for compound 4 lay 2.1-fold (0.32 log units) below the measured number; measured number inside the range.
By their numbers in this assay, from the lowest: compounds 2 and 1 (each within the scatter of the next); then compound 4. At a limit, above all of these: compound 3.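

Rearranging the same atoms within the group on the amide-type nitrogen, with the counted atoms, donors and acceptors unchanged, gives an at least 32-fold lower number from compound 3 to compound 4 (1.50 log units; beyond the scatter) in this assay, so at this position the way the group is joined matters and not only what it is made of. Compound 3 remains a limit of the assay and not a number: the limit of > 10000 nM in this assay, at which 1 of the 4 values shown sits. The rearranged group still falls well short of the two best groups, with a 46-fold higher number from compound 2 to compound 4 (1.67 log units; beyond the scatter) and a 40-fold higher number from compound 1 to compound 4 (1.60 log units; beyond the scatter) both standing as large steps.

The compounds shown leave open how far compound 3 lies past its limit, and with it the true size of the step to the rearranged group. They also leave open whether a single ring on the amide-type nitrogen, such as plain phenyl or pyridin-3-yl, would sit with the two best groups or with the other two.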